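Urea nitrogen substituent on the shared core: butyl to dimethoxyphenyl

The compounds below may be only part of what the source reports. "The series", "measured", "known", "first", "only" and "open" are said of these compounds alone.

Two ureas on the shared core carry the record so far. Compound 1 `O=C(NCCCOc1cccc(CN2CCCCC2)c1)Nc1ccc(C(F)(F)F)cc1` bears a 4-(trifluoromethyl)phenyl on the urea nitrogen and in an assay on isolated protein for inhibition of histamine H2 receptor (Cavia porcellus) (on this read-out lower numbers stand for tighter binding and higher numbers for weaker binding), compound 1 gives 1700 nM. Going by the values given here, compound 2 `CCCCNC(=O)NCCCOc1cccc(CN2CCCCC2)c1` carries butyl in that place, and in this assay compound 2 gives 81.3 nM, the lowest of the two numbers measured, with compound 1 as its only neighbour.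

Among the compounds with values here, the single measured step, a 21-fold lower number from compound 1 to compound 2 (1.32 log units; beyond the scatter), is the only direct guide for compound 3 `COc1ccc(OC)c(NC(=O)NCCCOc2cccc(CN3CCCCC3)c2)c1`. The change is 2,5-dimethoxyphenyl in place of butyl on an amide-type nitrogen. The entering group is again a six-membered aromatic ring on the urea nitrogen, as in compound 1, so the step from compound 2 to compound 3 is read as a partial reversal of the measured step: a higher number is expected, though the ring substituents differ from those of compound 1 and the size is uncertain.

The expected step is a 7.4-fold higher number from compound 2 to compound 3 (0.87 log units; beyond the scatter), and compound 3 is estimated at 600 nM in this assay, with a range from 150 nM to 2500 nM.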

Compound 3, dissociation constant: 158 nM
Compound 3: the middle estimate sits 3.8-fold (0.58 log units) above what was measured; measured number inside the range.
By their numbers in this assay, from the lowest: compounds 2 and 3 (each within the scatter of the next); then compound 1.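

The 2,5-dimethoxyphenyl group in place of butyl on an amide-type nitrogen gives a 1.9-fold higher number from compound 2 to compound 3 (0.29 log units; within the scatter) in this assay, so a six-membered aromatic ring at this place is compatible with a number within the scatter of the butyl urea, and compound 1 alone no longer stands for aromatic ureas at this position. The two aryl ureas separate clearly: 2,5-dimethoxyphenyl in place of 4-(trifluoromethyl)phenyl gives an 11-fold lower number from compound 1 to compound 3 (1.03 log units; beyond the scatter), which places the sensitivity of this position in the ring substituents rather than in the presence of the ring, although that reading rests on compound 1 and compound 3 alone. No available evidence bears on the reason for this separation between the two aryl ureas.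

Still open, on these data alone, is whether the high number of compound 1 belongs to the trifluoromethyl group itself or to the substitution pattern of its ring, a question that unsubstituted phenyl, 4-methoxyphenyl or 4-chlorophenyl on the urea nitrogen would address. The compounds shown also leave open whether a longer chain such as hexyl, or a saturated ring such as cyclohexyl, would hold the number of the butyl urea in this assay's range.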